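The compounds below may be only part of what the source reports. "The series", "measured", "known", "first", "only" and "open" are said of these compounds alone.

Compound 3 `Cc1ccc(C(=O)CSc2nc3ccccc3[nH]2)cc1` carries a methyl on an aromatic carbon. In a functional assay on HT-29 cells (Homo sapiens) for inhibition, read by WST assay, with a stated time of 48 h (a higher number here means a weaker inhibitor, a lower number a stronger inhibitor), compound 3 gives 34500 nM. For the measured compounds named here, only two of the three compounds give numbers here, and compound 3 sits beside compound 1 `O=C(CSc1nc2ccccc2[nH]1)c1ccc(O)cc1`, which in this assay gives 19200 nM; the step between them is a 1.8-fold higher number from compound 1 to compound 3 (0.25 log units; within the scatter). Compound 2 `CCOc1ccc(C(=O)CSc2nc3ccccc3[nH]2)cc1` gives in this assay only a limit, > 100000 nM, which is the limit of > 100000 nM in this assay, at which 1 of the 3 values shown sits. The steps of an at least 5.2-fold higher number from compound 1 to compound 2 (0.71 log units; beyond the scatter) and an at least 2.8-fold lower number from compound 2 to compound 3 (0.46 log units; beyond the scatter) show what swapping the group on this aromatic carbon has done so far.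

Compound 4 `O=C(CSc1nc2ccccc2[nH]1)c1ccc([N+](=O)[O-])cc1` differs from compound 3 by nitro in place of methyl on an aromatic carbon. Going by the values given here, no measured step brings in a nitro group, so the nearest guides are the swaps from hydroxy to methyl and from ethoxy to methyl on the aromatic carbon, which ran from within the scatter to at least modest. The step from compound 3 to compound 4 is therefore expected to be a 1.2-fold lower number from compound 3 to compound 4 (0.06 log units; within the scatter), with no clear direction. Compound 4 is estimated at 30000 nM, between 8000 nM and 120000 nM.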

Compound 4, half-maximal inhibitory concentration: 57000 nM
Beside the measured number, compound 4's estimate is 1.9-fold (0.28 log units) below it; the range from low to high includes it.
By their numbers in this assay, from the lowest: compounds 1, 3 and 4 (each within the scatter of the next, the first and the last beyond it). At a limit, above all of these: compound 2.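

Nitro, with more heavy atoms than methyl and two hydrogen-bond acceptors where methyl has none, still leaves this assay within the scatter on this aromatic carbon, with a 1.7-fold higher number from compound 3 to compound 4 (0.22 log units; within the scatter). Against hydroxy, however, the same group gives a 3.0-fold higher number from compound 1 to compound 4 (0.47 log units; beyond the scatter), the first step between two real numbers at this position that lies beyond the scatter. Compound 2 stands only at a limit, so its step is just a floor, an at least 1.7-fold lower number from compound 2 to compound 4 (0.24 log units; that floor lies within the scatter), and it sets no firm order with compound 4: the limit of > 100000 nM in this assay, at which 1 of the 4 values shown sits.

These four compounds leave open how an amine, a carboxylic acid or a longer chain on this aromatic carbon would read in this assay. As far as these compounds go, what changes elsewhere on the shared core would do also stays open.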